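Amide substituent variation on the shared core, step to compound 3

A few compounds are considered here, and "the series" means these few. Any claim that something is new, unique, unknown or untested is made for them only; others in the source may bear on it.

Measured compounds:
compound 1, `CCn1c(C(=O)N(C)CCC#N)ccc1C(CC)(CC)c1ccc(OCC(=O)C(C)(C)C)c(C)c1`, 9800 nM
compound 2, `CC[C@@H](C)[C@H](NC(=O)c1ccc(C(CC)(CC)c2ccc(OCC(=O)C(C)(C)C)c(C)c2)n1CC)C(=O)O`, 10 nM

Among the compounds with values here, in an assay on HL-60 cells for agonist activity at vitamin D3 receptor (Homo sapiens), read by microscopy, with a stated time of 96 h (on this read-out lower numbers stand for an effect already at smaller amounts and higher numbers for an effect only at larger amounts of compound), compound 2 gives 10 nM, the lowest of the two numbers measured so far; the nearest is compound 1 with 9800 nM. Within the data shown here, the only step measured within the pair is a 980-fold lower number from compound 1 to compound 2 (2.99 log units; beyond the scatter), in which a (1-carboxy-2-methylbutyl)amino group replaced a (2-cyanoethyl)(methyl)amino group on the carbonyl carbon.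

Compound 3, `CCn1c(C(=O)Nc2ccc(OC(F)(F)F)cc2)ccc1C(CC)(CC)c1ccc(OCC(=O)C(C)(C)C)c(C)c1`, differs from compound 2 in one place: 4-(trifluoromethoxy)phenyl in place of 1-carboxy-2-methylbutyl on an amide-type nitrogen. The group that leaves carries the carboxylic acid and both stereocentres; the group that enters is an aromatic ring bearing a trifluoromethoxy group, with no hydrogen-bond donor. Among the measured compounds shown here, the step of a 980-fold lower number from compound 1 to compound 2 (2.99 log units; beyond the scatter) is the only measured change that bears on this position, and it shows that the amide substituent can shift the number by a large amount. Compound 3 retains neither the acid nor the nitrile, so the measured steps give no direct guide; the expectation is that the number rises, estimated as a 300-fold higher number from compound 2 to compound 3 (2.48 log units; beyond the scatter). For compound 3 the estimate in this assay is 3000 nM, with a range from 300 nM to 30000 nM.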

Compound 3, half-maximal effective concentration: > 50000 nM
Compound 3 ended at the assay's limit (the forecaster's own chance of this, stated with the estimate: 15%); middle value at least 16-fold (1.22 log units) from the limit.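

In this assay the new comparison is an at least 5000-fold higher number from compound 2 to compound 3 (3.69 log units; beyond the scatter) on exchanging 1-carboxy-2-methylbutyl for 4-(trifluoromethoxy)phenyl on the amide-type nitrogen. Compound 3 keeps the amide hydrogen of compound 2 but not its low number, so the amide hydrogen alone does not give that number, a separation the first pair could not make since it changed both features at once. With an at least 5.1-fold higher number from compound 1 to compound 3 (0.70 log units; beyond the scatter) as the second comparison, the (4-(trifluoromethoxy)phenyl)amino group gives no lower number than (2-cyanoethyl)(methyl)amino, and of the three compounds only the one carrying 1-carboxy-2-methylbutyl reaches the low range; compound 3 stands at a limit of the assay and not at a number, so both steps are lower bounds: the limit of > 50000 nM in this assay, at which 1 of the 3 values shown sits.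

From the compounds shown here alone, it remains open whether the carboxylic acid alone accounts for the low number of compound 2 or whether the 2-methylbutyl chain and its two stereocentres contribute, a question that a methyl ester of the same group or a carboxylic acid on a shorter chain would address. Also open, going by these compounds, is whether a carboxylic acid on the phenyl ring, in place of trifluoromethoxy, would return the number to the low range.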